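Acetyl on the phenyl urea: expected effect on binding

The compounds below may be only part of what the source reports. "The series", "measured", "known", "first", "only" and "open" are said of these compounds alone.

Measured so far:
compound 1 `O=C(Nc1cc(F)cc(C(F)(F)F)c1)NC1CCN(C/C2=C/CCCCCC2)CC1`: 47 nM
compound 2 `CC1(C)[C@H]2CC=C(CN3CCC(NC(=O)Nc4ccccc4)CC3)[C@@H]1C2`: 2000 nM

In a functional assay on CHO cells for antagonist activity at C-X-C chemokine receptor type 3 (Homo sapiens), read by GTPgammaS binding (on this read-out higher numbers stand for weaker inhibition and lower numbers for stronger inhibition), compound 1 gives 47 nM. Compound 2 gives 2000 nM in this assay, the higher of the two numbers, with compound 1 well separated from it, beyond the scatter. Among the compounds with values here, the two differ in several places at once, so no single step between them can be read off.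

Compound 3 `CC(=O)c1cccc(NC(=O)NC2CCN(CC3=CC[C@H]4C[C@@H]3C4(C)C)CC2)c1` differs from compound 2 in one place: acetyl in place of hydrogen on an aromatic carbon. Within the data shown here, no measured pair shows this change on its own, so the direction is not fixed by the data. Among the measured compounds shown here, the one comparison available, compound 2 against compound 1, shows the unsubstituted phenyl at the high end, and compound 3 is therefore expected to give a lower number in this assay, a step larger than the scatter. The expected step is a 6.7-fold lower number from compound 2 to compound 3 (0.82 log units; beyond the scatter). Compound 3 is estimated at 300 nM, within 60 nM to 1500 nM.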

Compound 3, inhibition constant: 258 nM
For compound 3 the middle estimate is 1.2-fold (0.07 log units) above the measured one, and the stated range covers the measured number.
By their numbers in this assay, from the lowest: compound 1; then compound 3; then compound 2.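

In this assay, within the data shown here, the change from phenyl to 3-acetylphenyl gives the first step that can be read in one place: a 7.8-fold lower number from compound 2 to compound 3 (0.89 log units; beyond the scatter) with the rest of the structure unchanged. The aromatic carbon meta to a large group therefore accepts acetyl, and a bare phenyl is not needed at this place for the stronger inhibition seen with compound 3, which the earlier pair, differing in several places at once, could not show. Nothing at hand bears on the origin of this step.

From the compounds shown here alone, whether the lower number belongs to acetyl specifically remains open, and an amine, a carboxylic acid or a methyl ester at this same carbon would test that. Also open, going by these compounds, is whether acetyl gives a similar step on the core of compound 1.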